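Amide variation on the tetralin-methylamine series

A few compounds are considered here, and "the series" means these few. Any claim that something is new, unique, unknown or untested is made for them only; others in the source may bear on it.

Compound 1 `CN(CC(N)=O)C[C@@H]1CCCc2cc(S(=O)(=O)c3cccc(F)c3)ccc21` gives 1.26 nM in an assay on isolated protein for displacement of a labelled ligand from 5-hydroxytryptamine receptor 6 (Homo sapiens); on this read-out higher numbers stand for weaker inhibition and lower numbers for stronger inhibition. For the measured compounds named here, compound 2 `CC(=O)N(C)C[C@@H]1CCCc2cc(S(=O)(=O)c3cccc(F)c3)ccc21` gives 1.59 nM in this assay, the higher of the two numbers so far, with compound 1 as its nearest neighbour; the step of a 1.3-fold higher number from compound 1 to compound 2 (0.10 log units; within the scatter) lies within the scatter, so no order between the two can be read.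

Compound 3 `CC(C)(O)C(=O)NC[C@@H]1CCCc2cc(S(=O)(=O)c3cccc(F)c3)ccc21` is not yet measured. The change from compound 2 is ((1-hydroxy-1-methylethyl)carbonyl)amino in place of acetyl(methyl)amino on a saturated chain carbon bound to a saturated ring carbon. Going by the values given here, the one measured step, from compound 1 to compound 2, concerned the other substituent on the amine nitrogen and was small; it does not cover loss of the methyl on nitrogen nor the hydroxyl entering on the acyl group. Among the compounds with values here, with no direct precedent, a step in this assay beyond the scatter is not predicted, though the range is kept wide. For compound 3 the expected value in this assay is 3 nM, within 0.8 nM to 12 nM. This expectation corresponds to a step of a 1.9-fold higher number from compound 2 to compound 3 (0.28 log units; within the scatter) in this assay.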

Compound 3, inhibition constant: 2 nM
Compound 3: the middle estimate sits 1.5-fold (0.18 log units) above what was measured, within the range that was stated.
By their numbers in this assay, from the lowest: compounds 1, 2 and 3 (each within the scatter of the next).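

Placing ((1-hydroxy-1-methylethyl)carbonyl)amino in place of acetyl(methyl)amino on a saturated chain carbon bound to a saturated ring carbon gives, in this assay, a 1.3-fold higher number from compound 2 to compound 3 (0.10 log units; within the scatter), and placing it in place of (carbamoylmethyl)(methyl)amino gives a 1.6-fold higher number from compound 1 to compound 3 (0.20 log units; within the scatter). This position therefore shows no step beyond the scatter on going from a group of 5 heavy atoms with no hydrogen-bond donors to one of 7 heavy atoms with 2 hydrogen-bond donors. Nothing available bears on the reason for this.

The contributions of the lost methyl on nitrogen and the added hydroxyl remain unseparated, as compound 2 and compound 3 differ in both. Also open, on these data alone, is whether a carboxylic acid or a free amine at this place, or a longer chain on the acyl group, would stay within the scatter of these three compounds.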